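Cinnamamide Aryl Swap on a Trimethoxybenzophenone Core

The source may report more compounds than this note shows. Statements on the series, on what has been measured and on what is new or still open speak of the compounds shown alone.

Compound 1, `COc1ccc(C(=O)c2cc(OC)c(OC)c(OC)c2)cc1N`, gives 80 nM in a functional assay on ME-180 cells (Homo sapiens) for cytotoxicity, read by MTT assay, with a stated time of 72 h; a higher number here means a weaker inhibitor, a lower number a stronger inhibitor.
Compound 2, `COc1cccc(/C=C/C(=O)Nc2cc(OC)c(OC)c(OC)c2)c1`, gives 17300 nM in this assay.
Compound 3, `COc1cccc(/C=C/C(=O)Nc2cc(C(=O)c3cc(OC)c(OC)c(OC)c3)ccc2OC)c1`, gives 4300 nM in this assay.

Among the three measured compounds, compound 3 holds the second highest number in this assay. Its nearest neighbour is compound 2, whose number is higher by a margin beyond the scatter, while compound 1 stands furthest away, with a far lower number, also beyond the scatter. Compound 3 thus sits well apart from the most potent measured compound yet clearly ahead of compound 2.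

Compound 4, `COc1ccc(C(=O)c2cc(OC)c(OC)c(OC)c2)cc1NC(=O)/C=C/c1ccc(C(F)(F)F)cc1`, has not yet been measured. It differs from compound 3 in one place: 4-(trifluoromethyl)phenyl in place of 3-methoxyphenyl on a double-bonded chain carbon bound to a double-bonded chain carbon. The rest of the molecule, including the shared core and the amide-linked double-bonded chain, is unchanged.

Among the compounds with values here, no step between measured compounds is directly comparable to this change, so the expectation rests on compound 3 alone. The author expects the step of a 1.2-fold lower number from compound 3 to compound 4 (0.09 log units; within the scatter) to be small, in either direction, and likely not beyond the scatter. Compound 4 is therefore estimated at 3500 nM in this assay, with a range from 900 nM to 14000 nM.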

Compound 4, half-maximal inhibitory concentration: 800 nM
Compound 4: middle estimate off by 4.4-fold (0.64 log units), on the high side; the measured number lies below the stated range.
By their numbers in this assay, from the lowest: compound 1; then compound 4; then compound 3; then compound 2.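

In this assay the aryl group on the amide-linked double-bonded chain proves able to move the number: 4-(trifluoromethyl)phenyl in place of 3-methoxyphenyl on a double-bonded chain carbon bound to a double-bonded chain carbon gives a 5.4-fold lower number from compound 3 to compound 4 (0.73 log units; beyond the scatter) and this step lies beyond the scatter. The earlier compounds shown here offered no pair differing in one place, so they could not show that this position responds to a change of group while the shared core stays fixed. The step is a single exchange of one whole aryl group for another, yet the two groups differ both in their substituent and in where the name places it, so this one pair cannot separate those two differences.

The compounds shown leave open how a phenyl ring carrying a nitrile, an amine or a carboxylic acid in place of the trifluoromethyl group would fare on the same chain, and whether the lower number belongs to the trifluoromethyl group itself or would appear with other groups too. Nothing measured here speaks to why the exchange lowers the number.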